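Tolyl triazole sulfonamides: moving the methyl group

The source may hold more compounds than are shown below. What is called first, only, known or untested is meant among the compounds shown, and "the series" means these compounds.

Compound 1 `Cc1cccc(-n2cc(-c3ccccc3NS(=O)(=O)c3c[nH]c(=O)[nH]c3=O)nn2)c1` gives 1870 nM in a functional assay on A549 cells (Homo sapiens) for antiproliferative activity, read by MTT assay, with a stated time of 24 h; on this read-out lower numbers stand for stronger inhibition and higher numbers for weaker inhibition. Compound 2 `Cc1ccc(-n2cc(-c3ccccc3NS(=O)(=O)c3c[nH]c(=O)[nH]c3=O)nn2)cc1` gives 2910 nM in this assay; the change between them is 4-methylphenyl in place of 3-methylphenyl on an aromatic nitrogen, and it made a 1.6-fold higher number from compound 1 to compound 2 (0.19 log units; within the scatter). Compound 3 `Cc1cccc(-n2cc(-c3ccc(NS(=O)(=O)c4c[nH]c(=O)[nH]c4=O)cc3)nn2)c1` carries a different core; how that core differs from the core of compound 1 is not broken down here. In this assay compound 3 gives 6960 nM, the highest of the three numbers and beyond the scatter from both compound 1 and compound 2.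

Compound 4 `Cc1ccc(-n2cc(-c3ccc(NS(=O)(=O)c4c[nH]c(=O)[nH]c4=O)cc3)nn2)cc1` is not yet measured. It differs from compound 3 by 4-methylphenyl in place of 3-methylphenyl on an aromatic nitrogen, the same change at the same place as that from compound 1 to compound 2. In this assay the expected step is a 1.5-fold higher number from compound 3 to compound 4 (0.18 log units; within the scatter), set to match the earlier one because a 1.6-fold higher number from compound 1 to compound 2 (0.19 log units; within the scatter) lay within the scatter, so no real shift is expected. Compound 4 is therefore estimated at 10500 nM, with a likely range from 5000 nM to 22000 nM.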

Compound 4, half-maximal inhibitory concentration: 5560 nM
For compound 4 the middle estimate is 1.9-fold (0.28 log units) above the measured one; the range from low to high includes it.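

Replacing 3-methylphenyl with 4-methylphenyl on the aromatic nitrogen gave a 1.3-fold lower number from compound 3 to compound 4 (0.10 log units; within the scatter) in this assay, so this change stays within the scatter on the core of compound 3 as well. The steps on the two cores do not differ: the same change on two cores in this assay, a 1.6-fold higher number (0.19 log units; within the scatter) from compound 1 to compound 2 and a 1.3-fold lower number (0.10 log units; within the scatter) from compound 3 to compound 4, 1.9-fold (0.29 log units) apart, within the scatter of two such steps

Neither step lies beyond the scatter, so the pair shows that this change has no readable effect on either core, not that a step of real size would carry from one core to the other.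

Still open, going by these compounds, is whether a different group on that aromatic nitrogen, such as a 4-chlorophenyl, a 4-methoxyphenyl or a benzyl, would shift the number beyond the scatter. On these data alone, whether any such shift would hold on both cores is also open.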